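The compounds below may be only part of what the source reports. "The series", "measured", "known", "first", "only" and "open" are said of these compounds alone.

Measured compounds:
compound 1 `O=S1(=O)N=C(OCc2ccccc2)c2ccccc2N1Cc1ccc(Cl)c(Cl)c1` — 200000 nM
compound 2 `O=C1c2ccccc2N(Cc2ccccc2)S(=O)(=O)N1Cc1ccccc1` — > 50000 nM
compound 3 `O=C1c2ccccc2N(Cc2ccc(Cl)c(Cl)c2)S(=O)(=O)N1Cc1ccccc1` — 200000 nM

In a functional assay on HEL cells (Homo sapiens) (on this read-out lower numbers stand for higher toxicity in this test and higher numbers for lower toxicity in this test), compound 1 gives 200000 nM and compound 3 gives 200000 nM; the two sit level at the digits shown, within the scatter. For compound 2 this assay reports only a limit, > 50000 nM, not a number. The change phenyl in place of 3,4-dichlorophenyl on a saturated chain carbon bound to a sulfonamide nitrogen in a ring gives a step that the limit leaves unreadable from compound 3 to compound 2, whose size cannot be read because of the limit of > 50000 nM in this assay, at which 1 of the 3 values shown sits. Compound 1 and compound 3 carry the same atoms joined differently; the difference between the two cores is not broken down here.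

Compound 4 `O=S1(=O)N=C(OCc2ccccc2)c2ccccc2N1Cc1ccccc1` has not yet been measured in this assay. It differs from compound 1 by phenyl in place of 3,4-dichlorophenyl on a saturated chain carbon bound to a sulfonamide nitrogen in a ring, the same change as from compound 3 to compound 2, at a place worded identically in both cases. The earlier step is unreadable, and compound 2 itself sits at the limit, so for compound 4 the expectation rests only on compound 1 remaining roughly level: the expected step is no change at the digits printed from compound 1 to compound 4 (within the scatter). Compound 4 is estimated at 200000 nM. For compound 4 the expected range runs from 50000 nM to 500000 nM, with a fair chance that only a limit is reported.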

Compound 4, minimum cytotoxic concentration: 200000 nM
The estimate for compound 4 equals the measured number at the digits printed; low and high end bracket the measured number.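

In this assay, phenyl in place of 3,4-dichlorophenyl on a saturated chain carbon bound to a sulfonamide nitrogen in a ring gives no change at the digits printed from compound 1 to compound 4 (within the scatter). On the core of compound 3 the same change leads to compound 2, which has only a limit, so that step cannot be read: the limit of > 50000 nM in this assay, at which 1 of the 4 values shown sits. The result therefore shows that the two chlorines can go without a readable shift on the core of compound 1, but it does not show that the change carries over to the core of compound 3, since one readable step on one core offers no comparison.

The compounds shown leave open whether a group other than benzyl or 3,4-dichlorobenzyl at this place, such as a longer chain ending in an amine or a carboxylic acid, would shift the read-out from the level of compound 4, at 200000 nM. Also open, from the compounds shown here alone, is where compound 2 stands as a number, and with it how the two cores compare without the two chlorines.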